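The compounds below may be only part of what the source reports. "The series", "measured", "known", "first", "only" and "open" are said of these compounds alone.

Measured compounds in a functional assay on HeLa cells (Homo sapiens) for antiproliferative activity, read by MTT assay, with a stated time of 48 h; a higher number here means a weaker inhibitor, a lower number a stronger inhibitor:
- compound 1 `N#Cc1nc2c(-c3nc4ccccc4[nH]3)c(N)n(CCN3CCCC3)c2nc1C#N`; in this assay compound 1 gives > 50000 nM, which is a limit of the assay and not a number.
- compound 2 `CCN(CC)CCCn1c(N)c(-c2nc3ccccc3[nH]2)c2nc(C#N)c(C#N)nc21`; in this assay compound 2 gives 3150 nM.
- compound 3 `N#Cc1nc2c(-c3nc4ccccc4[nH]3)c(N)n(CCCO)c2nc1C#N`; in this assay compound 3 gives > 50000 nM, again a limit rather than a number.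

Compound 1 therefore stands at the limit of > 50000 nM in this assay, at which 2 of the 3 values shown sit, and only compound 2 returns a readable number. Among the compounds with values here, the one informative step is an at least 15-fold lower number from compound 1 to compound 2 (1.20 log units; beyond the scatter); in the other direction, an at least 15-fold higher number from compound 2 to compound 3 (1.20 log units; beyond the scatter), while a step that the two limits leave unreadable from compound 1 to compound 3.

Compound 4 `CN(C)CCCCCn1c(N)c(-c2nc3ccccc3[nH]2)c2nc(C#N)c(C#N)nc21` differs from compound 1 as follows: 3-(dimethylamino)propyl in place of pyrrolidin-1-yl on a saturated chain carbon, two bonds along the chain from an aromatic nitrogen.

Of the measured steps, only the move from compound 1 to compound 2 bears on this change: there too the pyrrolidin-1-yl ring is opened into a chain ending in a dialkylamino group, and the number fell by an at least 15-fold lower number from compound 1 to compound 2 (1.20 log units; beyond the scatter). Going by these compounds, the change to compound 4 is of the same kind, with a dimethylamino group on a longer chain, so a step of comparable size out of the limit is expected, although the longer chain is untested and the size is uncertain. For compound 4 the expected step is an at least 8.3-fold lower number from compound 1 to compound 4 (0.92 log units; beyond the scatter). Compound 4 is accordingly estimated at 6000 nM, with a range of 1500 nM to 40000 nM.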

Compound 4, half-maximal inhibitory concentration: 10800 nM
The estimate for compound 4 lay 1.8-fold (0.26 log units) below the measured number; low and high end bracket the measured number.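

In this assay, a second open-chain dialkylamino group, 5-(dimethylamino)pentyl in place of 2-(pyrrolidin-1-yl)ethyl, also moves the series off the limit, with an at least 4.6-fold lower number from compound 1 to compound 4 (0.66 log units; beyond the scatter), so the gain seen earlier is no longer carried by a single compound. The same group also stands clear of the hydroxy-ended chain, with an at least 4.6-fold lower number from compound 3 to compound 4 (0.66 log units; beyond the scatter). This position now has its first step between two readable numbers, a 3.4-fold higher number from compound 2 to compound 4 (0.54 log units; beyond the scatter), although the chain length and the alkyl groups on the amine change together in that step.

A 3-(dimethylamino)propyl or a 5-(diethylamino)pentyl chain would separate those two changes, and a 3-(pyrrolidin-1-yl)propyl chain would show whether the ring itself or the shorter chain of compound 1 goes with the lack of a readable number. Compound 1 and compound 3 both remain limits and not numbers, so the step between them cannot be read and any order between them stays open: the limit of > 50000 nM in this assay, at which 2 of the 4 values shown sit.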